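This account rests on a few compounds, and the source may have more. Where it says the series, first, only, none or still open, it means among the compounds named here.

Measured so far in an ADME assay on HEK293 cells (Homo sapiens) for cytotoxicity, read by ATP content, with a stated time of 6 h; a lower number here means that less compound is tolerated, a higher number that more compound is tolerated:
compound 1, `COCCCNc1nc(N)nc2ccn(Cc3ccccn3)c12` — a limit only, > 24000 nM
compound 2, `Cc1nnc(CNc2nc(N)nc3ccn(Cc4ccccn4)c23)o1` — a limit only, > 24000 nM

Compound 2 stands at the upper limit of this assay; the value quoted for it is a limit and not a number. Both values shown sit there: the limit of > 24000 nM in this assay, at which 2 of the 2 values shown sit. Going by the values given here, the only measured step, a step that the two limits leave unreadable from compound 1 to compound 2, is for that reason unreadable in size. Compound 3, `Nc1nc(NCc2ccon2)c2c(ccn2Cc2ccccn2)n1`, has not been measured; it differs from compound 2 as follows: 1,2-oxazol-3-yl in place of 5-methyl-1,3,4-oxadiazol-2-yl on a saturated chain carbon bound to a nitrogen on an aromatic ring. Among the compounds with values here, no measured step bears on this change, and neither measured value provides a number from which a shift in either direction could be read. For compound 3 the reading in this assay is expected to remain at the limit, so the estimated step that the limit leaves unreadable from compound 2 to compound 3 is expected to be none beyond the scatter. Compound 3 is estimated at 30000 nM, with a range from 15000 nM to 60000 nM, and is most likely to be reported as a limit only.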

Compound 3, half-maximal cytotoxic concentration: > 24000 nM
Compound 3 gave a limit, no number; the forecaster's own chance of this, stated with the estimate: 80%; the middle value is on the limit's open side.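

No step among compound 1, compound 2 and compound 3 can be read in this assay, where each value is a limit and not a number: the limit of > 24000 nM in this assay, at which 3 of the 3 values shown sit.

The compounds shown leave open whether the 2-methoxyethyl, 5-methyl-1,3,4-oxadiazol-2-yl and 1,2-oxazol-3-yl groups differ at all in this assay, and at what concentration any of the three compounds becomes cytotoxic.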